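Thiophen-2-yl for furan-2-yl: expectation for compound 4

The source may report more compounds than this note shows. Statements on the series, on what has been measured and on what is new or still open speak of the compounds shown alone.

Of the compounds shown here, three have been read in a functional assay on HCT-116 cells (Homo sapiens), read by MTT assay, with a stated time of 72 h (on this read-out lower numbers stand for stronger inhibition and higher numbers for weaker inhibition), and none has yet given a number. Compound 1 (`CN(C)c1ncnc2c1c(-c1ccsc1)cn2[C@@H]1O[C@H](CO)[C@@H](O)[C@H]1O`) gives > 20000 nM as a limit and not a number. Compound 2 (`Cc1nc(N)c2c(-c3ccoc3)cn([C@@H]3O[C@H](CO)[C@@H](O)[C@H]3O)c2n1`) gives > 20000 nM as a limit too. Compound 3 (`Nc1nc2c(c(-c3ccco3)cn2[C@@H]2O[C@H](CO)[C@@H](O)[C@H]2O)c(=O)[nH]1`) gives > 20000 nM as a limit as well. Going by the values given here, it therefore stands with the others, and the whole series so far is the limit of > 20000 nM in this assay, at which 3 of the 3 values shown sit, for now.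

Compound 4 (`Nc1nc2c(c(-c3cccs3)cn2[C@@H]2O[C@H](CO)[C@@H](O)[C@H]2O)c(=O)[nH]1`) differs from compound 3 in one place, with thiophen-2-yl in place of furan-2-yl on an aromatic carbon. Among the compounds with values here, no step between measured compounds is available to size this change in this assay for now. With compound 3 at > 20000 nM as a limit, no step beyond the scatter is expected in either direction. The expected change is a number no higher from compound 3 to compound 4 (the limit leaves the size open) on this estimate. Compound 4 is estimated at 20000 nM with an expected range from 7000 nM to 40000 nM and another reading at the limit is the likeliest outcome.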

Compound 4, half-maximal inhibitory concentration: 19800 nM
Compound 4: middle estimate off by 1.0-fold (0.00 log units), on the high side, and the stated range covers the measured number.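

In this assay, going by these compounds alone, compound 4 gives 19800 nM, the first actual number, so thiophen-2-yl on this aromatic carbon brings a reading inside the range of the assay. Compound 3 gives > 20000 nM, which is a limit and not a number. The exchange of furan-2-yl for thiophen-2-yl therefore gives a number no higher from compound 3 to compound 4 (the limit leaves the size open), a direction without a readable size, and the series otherwise stays where it was: the limit of > 20000 nM in this assay, at which 3 of the 4 values shown sit.

The compounds shown leave open whether this position can carry a stronger reading at all, as only five-membered aromatic rings with one hetero atom stand there. A phenyl ring or an aminomethyl group on this carbon of the core of compound 4 would test whether the number moves beyond the scatter.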